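This account rests on a few compounds, and the source may have more. Where it says the series, first, only, none or still open, it means among the compounds named here.

Measured so far in a functional assay on SF-295 cells (Homo sapiens) for inhibition, read by sulforhodamine B assay, with a stated time of 48 h; a lower number here means a stronger inhibitor of growth, a higher number a weaker inhibitor of growth:
compound 1 `COc1cc(-c2nn(-c3cccc(NC(=O)c4cccc(C(F)(F)F)c4)c3)cc2-c2ccncc2)ccc1Cl` 1020 nM
compound 2 `COc1cc(-c2nn(-c3cccc(NC(=O)Nc4ccc(Cl)c(C(F)(F)F)c4)c3)cc2-c2ccncc2)ccc1Cl` 840 nM

Compound 2 gives the lowest of the two numbers, but its gap to compound 1, a 1.2-fold lower number from compound 1 to compound 2 (0.08 log units; within the scatter), lies within the scatter, so the two stand level. Compound 3 `COc1cc(-c2nn(-c3cccc(NC(=O)c4ccccc4)c3)cc2-c2ccncc2)ccc1Cl` is the next member; against compound 2 the change is phenyl in place of (4-chloro-3-(trifluoromethyl)phenyl)amino on a carbonyl carbon. Going by the values given here, only one measured step touches this position, the one from compound 1 to compound 2, which also swapped the group on the carbonyl carbon and moved the number by a 1.2-fold lower number from compound 1 to compound 2 (0.08 log units; within the scatter), within the scatter. Among the compounds with values here, the move to compound 3 goes further, leaving a bare phenyl on that carbon without the trifluoromethyl, chlorine or the amino link; no measured pair covers that. The expected step is therefore small, a 1.8-fold higher number from compound 2 to compound 3 (0.25 log units; within the scatter), leaning toward a higher number. Compound 3 is estimated at 1500 nM in this assay, range 600 nM to 4000 nM.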

Compound 3, concentration for 50% growth inhibition: 337 nM
Compound 3: middle estimate off by 4.5-fold (0.65 log units), on the high side; the measured number lies below the stated range.
By their numbers in this assay, from the lowest: compound 3; then compounds 2 and 1 (each within the scatter of the next).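

In this assay, this position responds to the group on the carbonyl carbon: hydrogen in place of trifluoromethyl on an aromatic carbon gives a 3.0-fold lower number from compound 1 to compound 3 (0.48 log units; beyond the scatter), and phenyl in place of (4-chloro-3-(trifluoromethyl)phenyl)amino gives a 2.5-fold lower number from compound 2 to compound 3 (0.40 log units; beyond the scatter). Compounds 1 and 2 stood level and gave no sign of this; the unsubstituted phenyl of compound 3 is the first group here to separate from the others, and the substituents are not needed for growth inhibition among these three compounds. Nothing measured on these compounds accounts for the drop.

The step from compound 2 changes the amino link, the chlorine and the trifluoromethyl together, so their separate shares remain unresolved. Going by these compounds, whether a smaller group on that phenyl, such as methyl, methoxy or fluorine, keeps the lower number also stays open.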